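The source may report more compounds than this note shows. Statements on the series, on what has been measured and on what is new or still open speak of the compounds shown alone.

Compound 2 `O=C1C=C(Nc2ccccc2F)C(=O)c2c1nc1n2[C@H]2OC[C@@H](O)[C@H]2OC1` gives 2080 nM in a functional assay on MGC-803 cells (Homo sapiens) for inhibition, read by sulforhodamine B assay; a higher number here means a weaker inhibitor, a lower number a stronger inhibitor. Compound 1 `CCc1ccc(NC2=CC(=O)c3c(nc4n3[C@H]3OC[C@@H](O)[C@H]3OC4)C2=O)cc1` gives 1110 nM in this assay, and compound 3 `CCCc1ccc(NC2=CC(=O)c3c(nc4n3[C@H]3OC[C@@H](O)[C@H]3OC4)C2=O)cc1` gives 1920 nM. The gaps between compound 2 and the other two compounds both lie within the usual scatter, so compound 2 sits alongside them rather than apart. Compound 4 `O=C1C=C(Nc2cccc(Cl)c2)C(=O)c2c1nc1n2[C@H]2OC[C@@H](O)[C@H]2OC1` carries 3-chlorophenyl in place of 2-fluorophenyl on an amine nitrogen. Among the measured compounds shown here, no measured step alters the aromatic ring on the amine nitrogen in this way; the only measured step, a 1.7-fold higher number from compound 1 to compound 3 (0.24 log units; within the scatter), changes the saturated chain and stays within the scatter. On that basis the step from compound 2 to compound 4 is expected to be a 1.0-fold lower number from compound 2 to compound 4 (0.02 log units; within the scatter), with no change beyond the scatter. Compound 4 is therefore estimated at 2000 nM in this assay, between 900 nM and 4500 nM.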

Compound 4, half-maximal inhibitory concentration: 1770 nM
For compound 4 the middle estimate is 1.1-fold (0.05 log units) above the measured one; the measured number falls inside the stated range.
By their numbers in this assay, from the lowest: compounds 1, 4, 3 and 2 (each within the scatter of the next).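

In this assay, the step that alters the aromatic ring on the amine nitrogen, a 1.2-fold lower number from compound 2 to compound 4 (0.07 log units; within the scatter), stays within the scatter, so 2-fluorophenyl and 3-chlorophenyl read alike here. The earlier compounds shown here showed a change only in the saturated chain, whereas this step shows that the ring on the amine nitrogen can take either group with no change beyond the scatter. Nothing available explains this result. The step changes the halogen and its place on the ring together, so the two cannot be told apart. Going by these compounds, how an amine or a carboxylic acid on this ring would read in this assay stays open.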